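Chloro for bromo on an aromatic carbon: compound 3

This account rests on a few compounds, and the source may have more. Where it says the series, first, only, none or still open, it means among the compounds named here.

Measured so far:
Compound 1 `c1ccc(COc2nc3ccccc3s2)cc1`: 68.8%
Compound 2 `Brc1cccc(COc2nc3ccccc3s2)c1`: 77.6%

In a functional assay on the whole organism with Mus musculus as the target, with a stated time of 1 h, at a dose of 100 mg/kg by the intraperitoneal route (on this read-out lower numbers stand for less inhibition and higher numbers for more inhibition at the one dose given (going by the name of the read-out)), the two measured compounds sit close together. The step of a number 8.8 percentage points higher from compound 1 to compound 2 (within the scatter) lies within the scatter, so the two numbers are level on this evidence. Compound 3 `Clc1cccc(COc2nc3ccccc3s2)c1` differs from compound 2 by chloro in place of bromo on an aromatic carbon. For the measured compounds named here, the only measured step that bears on it is a number 8.8 percentage points higher from compound 1 to compound 2 (within the scatter), which concerns bromo entering on an aromatic carbon and was itself within the scatter; no measured pair sets one halogen against another at that place. The step in this assay is therefore expected to be small, a number 3.6 percentage points lower from compound 2 to compound 3 (within the scatter), with no direction beyond the scatter. Compound 3 is estimated at 74% in this assay, with a range from 58% to 88%.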

Compound 3, a percentage reported as inhibition, in the whole organism at one dose (the size of the read-out at that dose, not a potency): 80%
The estimate for compound 3 lay 6 percentage points below the measured number; measured number inside the range.
By their numbers in this assay, from the lowest: compounds 1, 2 and 3 (each within the scatter of the next, the first and the last beyond it).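

Chloro in place of bromo on an aromatic carbon gives a number 2.4 percentage points higher from compound 2 to compound 3 (within the scatter) in this assay, so the two halogens cannot be told apart at this place. Against hydrogen, chloro gives a number 11.2 percentage points higher from compound 1 to compound 3 (beyond the scatter), the first modest step in the series to lie beyond the scatter, while bromo, at a number 8.8 percentage points higher from compound 1 to compound 2 (within the scatter), stays within it, and this difference between the two halogen steps gives no ranking of chloro over bromo. Nothing measured here accounts for either step.

Going by these compounds, whether the step depends on a halogen remains open: an amine, a methoxy group or a carboxylic acid at this place could show that, and fluoro or iodo would extend the halogen comparison. The read-out at one dose also leaves open how the numbers would change at other doses.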